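The source may report more compounds than this note shows. Statements on the series, on what has been measured and on what is new or still open speak of the compounds shown alone.

Among the compounds with values here, in a functional assay on CFPAC-1 cells (Homo sapiens) for antiproliferative activity, read by MTT assay, with a stated time of 72 h (on this read-out lower numbers stand for stronger inhibition and higher numbers for weaker inhibition), compound 2 `CCCCc1cn(C[C@H](O)[C@H]2OC(=O)C(OCc3ccccc3)=C2OCc2ccccc2)nn1` gives 73200 nM, the only value in this small set that is a number rather than a limit. Compound 1 `CCCCCc1ccc(-c2cn(C/C=C3\OC(=O)C(OCc4ccccc4)=C3OCc3ccccc3)nn2)cc1` stops at the assay limit, > 100000 nM. Compound 3 `O=C1O/C(=C\Cn2cc(-c3cc(C(F)(F)F)cc(C(F)(F)F)c3)nn2)C(OCc2ccccc2)=C1OCc1ccccc1` also stops at the limit, > 100000 nM. Within the data shown here, compound 2 thus stands as the one measurable point among three weak inhibitors, and no step between measured compounds can be drawn, since two of them rest at the limit of > 100000 nM in this assay, at which 2 of the 3 values shown sit. Compound 4 `O=C1O[C@H]([C@@H](O)Cn2ccnn2)C(OCc2ccccc2)=C1OCc1ccccc1` differs from compound 2 by hydrogen in place of butyl on an aromatic carbon. Compound 4 is expected to give roughly 95000 nM, estimated between 40000 nM and 200000 nM. The expected step is a 1.3-fold higher number from compound 2 to compound 4 (0.11 log units; within the scatter), toward weaker inhibition but not clearly beyond the scatter, with a real chance that this assay reports only a limit.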

Compound 4, half-maximal inhibitory concentration: > 100000 nM
Compound 4 ended at the assay's limit; the forecaster's own chance of this, stated with the estimate: 55%; middle value at least 1.0-fold (0.02 log units) away from the limit.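

In this assay, within the data shown here, hydrogen in place of butyl on this aromatic carbon gives the first step that can be read here, an at least 1.3-fold higher number from compound 2 to compound 4 (0.13 log units; that floor lies within the scatter). That step is only a floor, so the data do not settle whether the butyl on the 4-butyl-1H-1,2,3-triazol-1-yl group contributes anything to the activity of compound 2. Compound 4 ends at a limit, joining the other compounds there: the limit of > 100000 nM in this assay, at which 3 of the 4 values shown sit.

From the compounds shown here alone, how far compound 4 truly lies from compound 2 remains open. So does whether a longer chain, an amine or a carboxylic acid on this carbon would give a measurable value.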